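Replacing 6-methoxypyridin-3-yl with benzyloxy in compound 2

The source may report more compounds than this note shows. Statements on the series, on what has been measured and on what is new or still open speak of the compounds shown alone.

Compound 1 `COc1cc(OCc2csc(-c3ccc(C(F)(F)F)cc3)n2)c2cc(-c3cn4nc(OC)sc4n3)oc2c1`: > 2 h (a limit of the assay)
Compound 2 `COc1cc(OCc2cccc(-c3ccc(OC)nc3)c2)c2cc(-c3cn4nc(OC)sc4n3)oc2c1`: 0.733 h
Compound 3 `COc1cc(OCc2csc(-c3ccccc3)n2)c2cc(-c3cn4nc(OC)sc4n3)oc2c1`: 1.33 h

In an ADME assay on microsomes from liver (Homo sapiens) for metabolic stability (a higher number here means that the compound lasts longer, a lower number that the compound disappears faster), compound 2 gives 0.733 h and compound 3 gives 1.33 h, two numbers within the scatter of each other. Compound 1 reports only a limit, > 2 h. Compound 4 `COc1cc(OCc2cccc(OCc3ccccc3)c2)c2cc(-c3cn4nc(OC)sc4n3)oc2c1` differs from compound 2 by benzyloxy in place of 6-methoxypyridin-3-yl on an aromatic carbon. For the measured compounds named here, the only measured step, an at least 1.5-fold lower number from compound 1 to compound 3 (0.17 log units; that floor lies within the scatter), is a different change, hydrogen in place of trifluoromethyl, and its floor lies within the scatter, so it sets no size or direction here. No step beyond the scatter is expected, and the expected step is a 1.1-fold lower number from compound 2 to compound 4 (0.05 log units; within the scatter). Compound 4 is estimated at 0.65 h, with an expected range of 0.3 h to 1.4 h.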

Compound 4, half-life: 1.43 h
Compound 4: middle estimate off by 2.2-fold (0.34 log units), on the low side; the whole stated range lies below it.
By their numbers in this assay, from the lowest: compounds 2, 3 and 4 (each within the scatter of the next). At a limit, above all of these: compound 1.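

In this assay, benzyloxy in place of 6-methoxypyridin-3-yl gives a 2.0-fold higher number from compound 2 to compound 4 (0.29 log units; within the scatter), the first step read at this position on the aromatic ring of carbon only. The position therefore takes either group, one with a ring nitrogen and methoxy and one with an oxygen link and a plain phenyl ring, with no step beyond the scatter. On these data alone, whether an amine or a carboxylic acid would be taken here stays open. A further upward step from compound 4 could also reach the top of the measure: the limit of > 2 h in this assay, at which 1 of the 4 values shown sits.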